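The source may report more compounds than this note shows. Statements on the series, on what has been measured and on what is new or still open speak of the compounds shown alone.

In a functional assay on blood (Homo sapiens), with a stated time of 60 min, in the presence of a further agent that is not named here (on this read-out lower numbers stand for an effect already at smaller amounts and higher numbers for an effect only at larger amounts of compound), three compounds built on a shared core have been measured. Compound 1 `O=C(OCc1ccccc1)C1(S(=O)(=O)c2ccc(Oc3ccc(OC(F)(F)F)cc3)cc2)CCC2(CCNCC2)C1` reaches only a limit of the assay, > 15000 nM. Compound 3 `Cc1ccc(-c2ccc(N)c(NC(=O)C3(S(=O)(=O)c4ccc(Oc5ccc(OC(F)(F)F)cc5)cc4)CCC4(CCNCC4)C3)c2)o1` also reaches only a limit, > 15000 nM. Going by the values given here, compound 2 `Nc1ccccc1NC(=O)C1(S(=O)(=O)c2ccc(Oc3ccc(OC(F)(F)F)cc3)cc2)CCC2(CCNCC2)C1` gives 900 nM, the only actual number in the set, while the remaining two results sit at the limit of > 15000 nM in this assay, at which 2 of the 3 values shown sit.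

Compound 2 is thus flanked by two large steps. Replacing benzyloxy on a carbonyl carbon with (2-aminophenyl)amino gives an at least 16-fold lower number from compound 1 to compound 2 (1.22 log units; beyond the scatter). Placing 5-methylfuran-2-yl in place of hydrogen on an aromatic carbon gives an at least 16-fold higher number from compound 2 to compound 3 (1.22 log units; beyond the scatter).

Compound 4 `CCCN1CCC2(CC1)CCC(C(=O)Nc1ccccc1N)(S(=O)(=O)c1ccc(Oc3ccc(OC(F)(F)F)cc3)cc1)C2` differs from compound 2 at a different place, with propyl in place of hydrogen on an amine nitrogen in a ring. Neither measured step touches that nitrogen, so both bear on the change only indirectly. The step to compound 3 shows that an added group elsewhere on compound 2 can move the number a long way, but it cannot be carried over in size.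

The estimated step is a 1.7-fold higher number from compound 2 to compound 4 (0.22 log units; within the scatter), a small one leaning towards a higher number. Compound 4 is expected at 1500 nM, with an estimated range from 400 nM to 6000 nM.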

Compound 4, half-maximal effective concentration: <= 400 nM
Compound 4: a limit, no number; the forecaster's own chance of this, stated with the estimate: 10%; middle value at least 3.7-fold (0.57 log units) away from the limit.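

In this assay, the amine nitrogen in the six-membered non-aromatic ring accepts an added chain with no loss of effect: propyl in place of hydrogen there gives an at least 2.2-fold lower number from compound 2 to compound 4 (0.35 log units; beyond the scatter). Going by these compounds alone, the only added group seen before on compound 2 was the 5-methylfuran-2-yl of compound 3, which went with a large step the other way, so compound 4 shows that enlarging compound 2 does not always cost effect, and that this nitrogen is a place where a gain can be had. Compound 4 stands at a limit, so the step is a bound and its full size remains unfixed: the limit of <= 400 nM in this assay, at which 1 of the 4 values shown sits.

The compounds shown have only hydrogen and propyl on this nitrogen, which leaves open whether methyl, a longer chain such as butyl, or a chain ending in a carboxylic acid would give a similar number. They also leave open whether propyl on this nitrogen would still lower the number in a compound that carries the 5-methylfuran-2-yl group on the aromatic carbon.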